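Swapping the Halogenated Ring in a Triazole Ether Series

The compounds below may be only part of what the source reports. "The series", "measured", "known", "first", "only" and "open" are said of these compounds alone.

In a physicochemical assay, read by spectrophotometry, with a stated time of 30 min (a lower number here means a stronger inhibitor, a higher number a weaker inhibitor), compound 1 `Clc1cccc(Cn2cc(COc3ccccc3)nn2)c1` gives 27.3 ug/mL. Compound 2 `Brc1ccc(Cn2cc(COc3ccccc3)nn2)cc1` carries 4-bromophenyl in place of 3-chlorophenyl on a saturated chain carbon bound to an aromatic nitrogen, and that change gave a 1.5-fold lower number from compound 1 to compound 2 (0.17 log units; within the scatter). Compound 3 `Cc1ccc(OCc2cn(Cc3cccc(Cl)c3)nn2)cc1` has a different core, differing from compound 1 by methyl in place of hydrogen on an aromatic carbon; that change gave a 1.7-fold lower number from compound 1 to compound 3 (0.22 log units; within the scatter). In this assay compound 3 gives 16.3 ug/mL, and compound 2 gives 18.3 ug/mL; all three numbers sit close together. Compound 4 `Cc1ccc(OCc2cn(Cc3ccc(Br)cc3)nn2)cc1` has not been measured yet. It differs from compound 3 by 4-bromophenyl in place of 3-chlorophenyl on a saturated chain carbon bound to an aromatic nitrogen, the same change already made from compound 1 to compound 2, now on the methyl-bearing core. Because the earlier change gave a 1.5-fold lower number from compound 1 to compound 2 (0.17 log units; within the scatter), a step of similar size, a 1.4-fold lower number from compound 3 to compound 4 (0.13 log units; within the scatter), is expected here. Compound 4 is therefore estimated at 12 ug/mL, likely between 6 ug/mL and 24 ug/mL.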

Compound 4, half-maximal inhibitory concentration: 16.3 ug/mL
Compound 4: middle estimate off by 1.4-fold (0.13 log units), on the low side; measured number inside the range.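

In this assay, putting 4-bromophenyl in place of 3-chlorophenyl on the methyl-bearing core gives no change at the digits printed from compound 3 to compound 4 (within the scatter), while methyl in place of hydrogen on an aromatic carbon gives a 1.1-fold lower number from compound 2 to compound 4 (0.05 log units; within the scatter). The same ring swap on the core of compound 1 gave a 1.5-fold lower number from compound 1 to compound 2 (0.17 log units; within the scatter), so the swap shows no detectable difference between the two cores, but steps this small do not show that it has a real effect on either core, or the same effect on both. No supporting data bear on these results.

The compounds shown leave open how an amine or a carboxylic acid in place of the halogen would read. They also leave open what a longer chain in place of the methyl would do.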